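The source may hold more compounds than are shown below. What is called first, only, known or untested is meant among the compounds shown, and "the series" means these compounds.

Among three compounds measured in a functional assay on SMMC-7721 cells (Homo sapiens) for antiproliferative activity, read by MTT assay, with a stated time of 72 h (a lower number here means a stronger inhibitor, a higher number a weaker inhibitor), compound 3 `Cc1nn(C)c(Oc2ccc(F)cc2)c1/C=N\OCc1c(Cl)c(-c2ccc(Cl)cc2)nn1C` gives 3230 nM and is the strongest inhibitor; compound 1 `Cc1nn(C)c(Oc2ccc(F)cc2)c1/C=N\OCc1c(Cl)c(-c2ccc(F)cc2)nn1C` gives 6640 nM and compound 2 `Cc1nn(C)c(Oc2ccc(Cl)cc2)c1/C=N\OCc1c(Cl)c(-c2ccc(F)cc2)nn1C` gives 7970 nM. Compound 4 `Cc1nn(C)c(Oc2ccc(Cl)cc2)c1/C=N\OCc1c(Cl)c(-c2ccc(Cl)cc2)nn1C` differs from compound 3 by one change: chloro in place of fluoro on an aromatic carbon, turning 4-fluorophenoxy into 4-chlorophenoxy. The same exchange at the same place was seen once before, as a 1.2-fold higher number from compound 1 to compound 2 (0.08 log units; within the scatter), so a step within the scatter. The other exchange, a 2.1-fold lower number from compound 1 to compound 3 (0.31 log units; beyond the scatter), concerns a different ring and bears less directly. For compound 4 the expected step is therefore a 1.1-fold higher number from compound 3 to compound 4 (0.05 log units; within the scatter), essentially no movement beyond the scatter. The estimate for compound 4 in this assay is 3600 nM, with a range from 1800 nM to 7200 nM.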

Compound 4, half-maximal inhibitory concentration: 6820 nM
Beside the measured number, compound 4's estimate is 1.9-fold (0.28 log units) below it; the measured number falls inside the stated range.
By their numbers in this assay, from the lowest: compound 3; then compounds 1, 4 and 2 (each within the scatter of the next).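

The 4-fluorophenoxy to 4-chlorophenoxy change, which stayed within the scatter on the core of compound 1, gives a 2.1-fold higher number from compound 3 to compound 4 (0.32 log units; beyond the scatter) on the core of compound 3. The 4-fluorophenyl to 4-chlorophenyl change, which gave a lower number on the core of compound 1, gives only a 1.2-fold lower number from compound 2 to compound 4 (0.07 log units; within the scatter) on the core of compound 2. Still, the two readings of the first change are not firmly different: the same change on two cores in this assay, a 1.2-fold higher number (0.08 log units; within the scatter) from compound 1 to compound 2 and a 2.1-fold higher number (0.32 log units; beyond the scatter) from compound 3 to compound 4, 1.8-fold (0.25 log units) apart, within the scatter of two such steps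

The compounds shown carry only fluoro or chloro at these places. Going by these compounds, how a methoxy group, an amine or a carboxylic acid there would behave stays open.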